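The compounds below may be only part of what the source reports. "The series", "measured", "known", "first", "only" and "open" are said of these compounds alone.

The measured compounds, all sharing one core:

compound 1, `Cc1cccc(/C=N/Nc2ncc3c(n2)n(C2CCCC2)c(=O)c(=O)n3C)c1`, gives 53600 nM in a functional assay on PC-3 cells (Homo sapiens) for antiproliferative activity, read by MTT assay; a lower number here means a stronger inhibitor, a higher number a weaker inhibitor;
compound 2, `Cn1c(=O)c(=O)n(C2CCCC2)c2nc(N/N=C/c3ccco3)ncc21`, gives 72200 nM in this assay;
compound 3, `Cn1c(=O)c(=O)n(C2CCCC2)c2nc(N/N=C/c3ccc(F)cc3Cl)ncc21`, gives 15200 nM in this assay.

Compound 3 gives the lowest number of the three: the step from compound 1 is a 3.5-fold lower number from compound 1 to compound 3 (0.55 log units; beyond the scatter), and the step from compound 2 is a 4.8-fold lower number from compound 2 to compound 3 (0.68 log units; beyond the scatter). These two steps are the only ones that speak to the place where compound 4 differs, and both are modest.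

Compound 4, `Cn1c(=O)c(=O)n(C2CCCC2)c2nc(N/N=C/c3ccc(O)c(Br)c3)ncc21`, has not yet been measured. It differs from compound 3 in one way: 3-bromo-4-hydroxyphenyl in place of 2-chloro-4-fluorophenyl on a carbon with a double bond to nitrogen. Among the measured compounds shown here, none of the measured compounds carries a hydroxyl or a bromine on that ring, so the measured steps give no direct guide to this particular pair of groups; they show only that swapping the ring at this place has moved the number by modest amounts in either direction. Compound 4 is therefore expected to land within the span the three measured compounds cover, most likely somewhat weaker than compound 3, a step of a 1.6-fold higher number from compound 3 to compound 4 (0.22 log units; within the scatter). The estimate for compound 4 is 25000 nM, with a range from 8000 nM to 80000 nM.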

Compound 4, half-maximal inhibitory concentration: 11600 nM
Beside the measured number, compound 4's estimate is 2.2-fold (0.33 log units) above it, and the stated range covers the measured number.
By their numbers in this assay, from the lowest: compounds 4 and 3 (each within the scatter of the next); then compounds 1 and 2 (each within the scatter of the next).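

In this assay, 3-bromo-4-hydroxyphenyl in place of 2-chloro-4-fluorophenyl gives a 1.3-fold lower number from compound 3 to compound 4 (0.12 log units; within the scatter) and so shows that this place can take two rings with different atoms, one with a hydrogen-bond donor and one without, with no difference beyond the scatter. The new ring also gives a 6.2-fold lower number from compound 2 to compound 4 (0.79 log units; beyond the scatter) and a 4.6-fold lower number from compound 1 to compound 4 (0.66 log units; beyond the scatter) as modest steps, so compound 4 joins compound 3 apart from the compounds carrying furan-2-yl and 3-methylphenyl. No outside evidence bears on why these rings compare as they do.

The compounds shown leave open what the hydroxyl and the bromine each contribute alone, as the two always come together here. Also open, as far as these compounds go, is how a ring carrying an amine or a carboxylic acid would compare at this place.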